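Shortening the Amide Chain on a Dibromo Thioether

A few compounds are considered here, and "the series" means these few. Any claim that something is new, unique, unknown or untested is made for them only; others in the source may bear on it.

Compound 2 `CCCCNC(=O)CSC(c1ccc(Br)cc1)c1ccc(Br)cc1` places two bromine-bearing rings on a carbon joined through sulfur to a chain that ends in a butylcarbamoyl group. In an assay on brain (strain Sprague-Dawley) for displacement of a labelled ligand from sodium-dependent dopamine transporter (Rattus norvegicus), read by scintillation counting, with a stated time of 120 min (on this read-out higher numbers stand for weaker inhibition and lower numbers for stronger inhibition), compound 2 gives 722 nM. Among the three compounds measured, compound 2 stands second highest. Its nearest neighbour is compound 1 `NCCSC(c1ccc(Br)cc1)c1ccc(Br)cc1`, which in this assay gives 483 nM. The step of a 1.5-fold higher number from compound 1 to compound 2 (0.17 log units; within the scatter) separates them, so the two are read as alike. Furthest away is compound 3 `CCCCNC(=O)CSC(c1ccccc1)c1ccccc1`, which carries no bromine and in this assay gives 23600 nM, a gap beyond the scatter.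

Compound 4 `CNC(=O)CSC(c1ccc(Br)cc1)c1ccc(Br)cc1` differs from compound 2 in one place: hydrogen in place of propyl on a saturated chain carbon bound to an amide-type nitrogen. Among the measured compounds shown here, only one measured step bears on this end of the molecule: the exchange recorded as a 1.5-fold higher number from compound 1 to compound 2 (0.17 log units; within the scatter), which swapped the whole tail and still left the number within the scatter. For the measured compounds named here, no measured step shortens the chain on the amide nitrogen itself, so there is nothing to suggest a movement beyond the scatter in either direction.

Compound 4 is therefore expected to give about 800 nM in this assay, with a plausible range from 300 nM to 2500 nM. The expected step of a 1.1-fold higher number from compound 2 to compound 4 (0.04 log units; within the scatter) is estimated to stay within the scatter.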

Compound 4, inhibition constant: 3010 nM
Compound 4: the middle estimate sits 3.8-fold (0.58 log units) below what was measured, outside the stated range (above it).
By their numbers in this assay, from the lowest: compounds 1 and 2 (each within the scatter of the next); then compound 4; then compound 3.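

The earlier compounds shown here held no step at the far end of the amide, and here butyl to methyl on the amide nitrogen gives a 4.2-fold higher number from compound 2 to compound 4 (0.62 log units; beyond the scatter) in this assay, a shift towards weaker inhibition. Among the compounds shown here, the length of this chain therefore registers in the number, even though the first exchange of the whole tail stayed within the scatter. The same holds against the amine: butylcarbamoyl and aminomethyl read alike, yet methylcarbamoyl in place of aminomethyl gives a 6.2-fold higher number from compound 1 to compound 4 (0.79 log units; beyond the scatter), so among these compounds the amide tail matches the amine tail only when it carries butyl. No measurement at hand gives a reason for this shift.

The compounds shown leave open how the number moves with chains of in-between length on the amide nitrogen, such as ethyl or propyl, and whether a longer chain such as hexyl would lower it further. They also leave open what a phenyl ring on that nitrogen, or a carboxylic acid in place of the amide, would give.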